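Sulfonamide for Methoxy: Stability Expected to Stay at Limit

The source may report more compounds than this note shows. Statements on the series, on what has been measured and on what is new or still open speak of the compounds shown alone.

Compound 1 `COc1cc(C2CCNCC2)ccc1Nc1ncc2ccc(-c3ccccc3N(C)S(C)(=O)=O)n2n1`: > 0.666 h
Compound 2 `COc1cc(C2CCN(CC(N)=O)CC2)ccc1Nc1ncc2ccc(-c3ccccc3OC)n2n1`: > 0.666 h

In an in vitro ADME assay on microsomes from liver (Mus musculus, strain CD1) for metabolic stability, using NADPH, with a stated time of 10 min, tested at 0.5 uM (on this read-out lower numbers stand for a shorter-lived compound and higher numbers for a longer-lived compound), compound 2 gives > 0.666 h, which is a limit of the assay rather than a number. Compound 1 likewise sits at a limit, > 0.666 h. Both values shown rest at the limit of > 0.666 h in this assay, at which 2 of the 2 values shown sit. Compound 3 `COc1cc(C2CCN(CC(N)=O)CC2)ccc1Nc1ncc2ccc(-c3ccccc3N(C)S(C)(=O)=O)n2n1` differs from compound 2 by methyl(methylsulfonyl)amino in place of methoxy on an aromatic carbon. Among the measured compounds shown here, no single-change step between measured compounds exists here, so the size of this step is untested. Compound 3 is expected to remain at the limit as well, the step estimated as a step that the limit leaves unreadable from compound 2 to compound 3, no larger than the scatter. Compound 3 is therefore estimated at 0.8 h, between 0.4 h and 2 h.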

Compound 3, half-life: 0.483 h
Beside the measured number, compound 3's estimate is 1.7-fold (0.22 log units) above it; low and high end bracket the measured number.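

In this assay compound 3 alone gives a number rather than a limit, so methyl(methylsulfonyl)amino in place of methoxy on an aromatic carbon yields an at least 1.3-fold lower number from compound 2 to compound 3 (0.13 log units; that floor lies within the scatter). Carbamoylmethyl in place of hydrogen on an amine nitrogen in a ring yields an at least 1.3-fold lower number from compound 1 to compound 3 (0.13 log units; that floor lies within the scatter). Both steps are only floors, because the other two compounds give no number: the limit of > 0.666 h in this assay, at which 2 of the 3 values shown sit.

As far as these compounds go, the true size of either step remains open. So does how a plain amine or a methylsulfonyl group would read on the same aromatic carbon.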